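Swapping a Pyrazole for an Amide on a Silent Core

The source may hold more compounds than are shown below. What is called first, only, known or untested is meant among the compounds shown, and "the series" means these compounds.

Compound 1 `c1cc(-c2cn[nH]c2)c2c(c1)C(c1ncc[nH]1)CC2` was tested in a functional assay on CHO cells for agonist activity at Alpha-1B adrenergic receptor (Homo sapiens), read by FLIPR and calcium flux; a higher number here means that more compound is needed for the effect, a lower number that less compound is needed. Compound 1 gives > 10000 nM, which is a limit of the assay rather than a number. Compound 2 `Cc1c(OCC2=NCCN2)ccc(Cl)c1NS(C)(=O)=O` also gives > 10000 nM, again a limit. Compound 3 `Cc1ccc2c(c1NS(C)(=O)=O)CCC2c1ncc[nH]1` gives > 10000 nM, a limit as well. All values shown sit at the same point: the limit of > 10000 nM in this assay, at which 3 of the 3 values shown sit.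

Compound 4 `CNC(=O)c1cccc2c1CCC2c1ncc[nH]1` differs from compound 1 by methylcarbamoyl in place of 1H-pyrazol-4-yl on an aromatic carbon. For the measured compounds named here, no step between two measured compounds is known, so the size of this change cannot be read from the data, and the expectation is for no step beyond the scatter.

Compound 4 is expected to give about 15000 nM, within a range from 5000 nM to 50000 nM. This estimate corresponds to a step that the limit leaves unreadable from compound 1 to compound 4.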

Compound 4, half-maximal effective concentration: > 10000 nM
Compound 4 ended at the assay's limit; the forecaster's own chance of this, stated with the estimate: 80%; the middle value is on the limit's open side.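

For the compounds shown here, compound 1 and compound 4 both end at a limit rather than at a number, so no step between them can be read. The compounds shown leave open whether any of them gives a measurable effect in this assay: the limit of > 10000 nM in this assay, at which 4 of the 4 values shown sit.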